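Replacing Isopropyl with (Methylsulfonyl)methyl: Cell Tolerance

A few compounds are considered here, and "the series" means these few. Any claim that something is new, unique, unknown or untested is made for them only; others in the source may bear on it.

Measured in an ADME assay on HeLa cells (Homo sapiens) for cytotoxicity, read by ATP content, with a stated time of 3 days; a higher number here means that more compound is tolerated, a lower number that less compound is tolerated:
- Compound 1 `CC(C)CCn1c(Cn2c(=O)n(C3CC3)c3ccncc32)cc2cnccc21` gives > 50000 nM, which is a limit of the assay rather than a number.
- Compound 2 `CS(=O)(=O)CCCn1c(Cn2c(=O)n(C3CC3)c3ccncc32)cc2ccccc21` gives > 100000 nM, again a limit of the assay.
- Compound 3 `CC(C)CCn1c(Cn2c(=O)n(C3CC3)c3ccncc32)cc2ccccc21` gives > 100000 nM, also a limit of the assay.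

Compound 3 and compound 2 differ by one change, ((methylsulfonyl)methyl in place of isopropyl on a saturated chain carbon, two bonds along the chain from an aromatic nitrogen). The step that the two limits leave unreadable from compound 3 to compound 2 cannot be sized, as both ends are limits; what can be said is that the limit of > 100000 nM in this assay, at which 2 of the 3 values shown sit, holds for both.

Compound 4 `CS(=O)(=O)CCCn1c(Cn2c(=O)n(C3CC3)c3ccncc32)cc2cnccc21` is not yet measured. It arises from compound 1 by the same change, ((methylsulfonyl)methyl in place of isopropyl on a saturated chain carbon, two bonds along the chain from an aromatic nitrogen), and the place of the change is the same in words for both pairs. The difference between the core of compound 1 and the core of compound 3 is not broken down here.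

The step that the limit leaves unreadable from compound 1 to compound 4 is expected to be small, since the same change from compound 3 to compound 2 left both values at a limit and compound 1 already sits at the limit of > 50000 nM in this assay, at which 1 of the 3 values shown sits. Compound 4 is therefore estimated at 100000 nM in this assay, with a range from 50000 nM to 300000 nM, most likely reported only as a limit.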

Compound 4, half-maximal cytotoxic concentration: > 50000 nM
Compound 4 was reported as a limit; the forecaster's own chance of this, stated with the estimate: 90%; the middle value is on the limit's open side.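

Compound 1 and compound 4 are both reported only as limits of the assay, so no size can be read for the step between them. The compounds shown leave open where the half-maximal cytotoxic concentration of each one truly lies, and so whether putting (methylsulfonyl)methyl in place of isopropyl changes it at all.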